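A few compounds are considered here, and "the series" means these few. Any claim that something is new, unique, unknown or untested is made for them only; others in the source may bear on it.

Compound 3 `CCC(C)C(NC(=O)c1ccc(C(CC)(CC)c2ccc(OCCC(O)(CC)CC)c(C)c2)n1CC)C(=O)O` stands at the high end of the two numbers available in an assay on cells for agonist activity at vitamin D3 receptor (Homo sapiens), with a stated time of 96 h; a lower number here means that less compound is needed, a higher number that more compound is needed for the effect: in this assay compound 3 gives 860 nM. Its nearest neighbour in the series is compound 1 `CCn1c(C(=O)NCCN(C)C)ccc1C(CC)(CC)c1ccc(OCCC(O)(CC)CC)c(C)c1`, and in this assay compound 1 gives 82 nM. Compound 2 `CCn1c(C(=O)N(CCC#N)CCC#N)ccc1C(CC)(CC)c1ccc(OCCC(O)(CC)CC)c(C)c1` sits in this assay at > 10000 nM, which is a limit of the measurement and not a number.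

Compound 4 `CCn1c(C(=O)N(C)CC(=O)O)ccc1C(CC)(CC)c1ccc(OCCC(O)(CC)CC)c(C)c1` has not yet been measured. It differs from compound 3 in one place: (carboxymethyl)(methyl)amino in place of (1-carboxy-2-methylbutyl)amino on a carbonyl carbon. Within the data shown here, two measured steps bear on this change. The step of a 10-fold higher number from compound 1 to compound 3 (1.02 log units; beyond the scatter) shows that exchanging what sits on the amide nitrogen can shift the number a great deal. The step of an at least 11-fold lower number from compound 2 to compound 3 (1.06 log units; beyond the scatter) runs the other way, from the limit down to a measured number, and it too involves a change on the carbonyl carbon. Compound 4 keeps a carboxylic acid, as in compound 3, but the entering group carries one hydrogen-bond donor fewer, which brings it closer in that respect to compound 2.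

Weighing these, the step from compound 3 to compound 4 is expected to be a 2.1-fold higher number from compound 3 to compound 4 (0.32 log units; beyond the scatter), a moderate rise. Compound 4 is therefore estimated at 1800 nM, within a range from 350 nM to 9000 nM.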

Compound 4, half-maximal effective concentration: 89 nM
The estimate for compound 4 lay 20-fold (1.31 log units) above the measured number, and the stated range ends above it.
By their numbers in this assay, from the lowest: compounds 1 and 4 (each within the scatter of the next); then compound 3. At a limit, above all of these: compound 2.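

In this assay, the change on the carbonyl carbon gives a 9.7-fold lower number from compound 3 to compound 4 (0.99 log units; beyond the scatter), so a carboxylic acid in this group does not by itself hold the number at the level of the (1-carboxy-2-methylbutyl)amino compound; the group around the acid matters as well. Exchanging the (2-(dimethylamino)ethyl)amino group, which ends in an amine, for the (carboxymethyl)(methyl)amino group, which ends in a carboxylic acid, gives a 1.1-fold higher number from compound 1 to compound 4 (0.04 log units; within the scatter), so this pair shows that two quite different chain ends can give values that cannot be told apart here. The remaining step, an at least 110-fold lower number from compound 2 to compound 4 (2.05 log units; beyond the scatter), starts from a limit and not from a number, so it gives only a bound on the size of the change: the limit of > 10000 nM in this assay, at which 1 of the 4 values shown sits.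

The change from compound 3 to compound 4 alters two things at once, the branched side chain and the amide hydrogen, which is replaced by a methyl group, so the compounds shown cannot say which of the two accounts for the step. As far as these compounds go, a simple carboxymethylamino group with the amide hydrogen kept, or the same branched acid with a methyl on the amide nitrogen, would separate them, and a longer chain before the acid remains untested here.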